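The compounds below may be only part of what the source reports. "The series", "measured", "known", "first", "only" and "open" are said of these compounds alone.

Compound 1, `Fc1ccc([B-]2(c3ccccc3)[NH2+]CCO2)cc1`, gives 18800 nM in an assay on HEK293 cells for inhibition of transient receptor potential cation channel subfamily V member 6 (Homo sapiens), read by FLIPR and calcium flux, with a stated time of 5 min; on this read-out higher numbers stand for weaker inhibition and lower numbers for stronger inhibition.
Compound 2, `CCCCc1ccc([B-]2(c3ccccc3)[NH2+]CCO2)cc1`, gives 14300 nM in this assay.

Going by the values given here, on these two numbers compound 2 carries the lower one, but its only neighbour is compound 1, and the step of a 1.3-fold lower number from compound 1 to compound 2 (0.12 log units; within the scatter) lies within the scatter, so the two cannot be told apart on this read-out.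

Compound 3, `Brc1ccc([B-]2(c3ccccc3)[NH2+]CCO2)cc1`, has not yet been measured. It differs from compound 2 by bromo in place of butyl on an aromatic carbon: butyl leaves and bromo enters, on an aromatic carbon of a six-membered aromatic ring of carbon only, para to a large group; neither group brings hydrogen-bond donors, hydrogen-bond acceptors or a net charge.

Among the compounds with values here, only one measured step touches this position, a 1.3-fold lower number from compound 1 to compound 2 (0.12 log units; within the scatter), in which fluoro gave way to butyl without moving the number beyond the scatter. With a halogen and a butyl already giving indistinguishable numbers there, bromo at the same place is expected to do much the same, so the step of a 1.1-fold higher number from compound 2 to compound 3 (0.05 log units; within the scatter) is expected to stay within the scatter. For compound 3 the estimate in this assay is 16000 nM, with a range from 7000 nM to 36000 nM.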

Compound 3, half-maximal inhibitory concentration: 13200 nM
Estimate against measurement, compound 3: 1.2-fold (0.08 log units) above, and the stated range covers the measured number.
By their numbers in this assay, from the lowest: compounds 3, 2 and 1 (each within the scatter of the next).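

In this assay, going by these compounds alone, replacing butyl with bromo gives no step that can be told from the scatter (a 1.1-fold lower number from compound 2 to compound 3 (0.03 log units; within the scatter)), and neither does replacing fluoro with bromo (a 1.4-fold lower number from compound 1 to compound 3 (0.15 log units; within the scatter)). Compounds 1, 2 and 3 therefore form a single group on this read-out: with one measured pair, the lack of separation could have been particular to fluoro and butyl, but it now holds across three groups, including butyl with 4 heavy atoms and bromo with 1 heavy atom. Nothing available explains why these three groups cannot be separated.

The compounds shown leave open whether an amine, a carboxylic acid or a longer chain on this aromatic carbon would move the number beyond the scatter, since none of the three groups here brings a hydrogen-bond donor, a hydrogen-bond acceptor or a net charge. They also leave open whether changes elsewhere on the shared core would matter more than changes at this position.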